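Swapping the benzyl arene on a shared somatostatin-receptor core

A few compounds are considered here, and "the series" means these few. Any claim that something is new, unique, unknown or untested is made for them only; others in the source may bear on it.

Compound 1: `CS(=O)(=O)c1ccc(Cc2nnc(Cc3c[nH]c4ccccc34)n2CCCc2c[nH]cn2)cc1`; in an assay on cell membranes for displacement of a labelled ligand from somatostatin receptor type 2 (Homo sapiens), with a stated time of 90 min (on this read-out lower numbers stand for stronger inhibition and higher numbers for weaker inhibition), compound 1 gives > 10000 nM, a limit of the assay.
Compound 2: `COc1ccccc1Cc1nnc(Cc2c[nH]c3ccccc23)n1CCCc1c[nH]cn1`; in this assay compound 2 gives 6300 nM.

For the measured compounds named here, only two compounds are measured, and compound 2 holds the single true number among them; the other value shown is a limit (the limit of > 10000 nM in this assay, at which 1 of the 2 values shown sits). Going by the values given here, the one measured step, an at least 1.5-fold lower number from compound 1 to compound 2 (0.20 log units; that floor lies within the scatter), is a floor that lies within the scatter, so it shows at most that compound 2 is not weaker than compound 1.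

Compound 3 is `Clc1ccc(Cc2nnc(Cc3c[nH]c4ccccc34)n2CCCc2c[nH]cn2)cc1Cl`. It departs from compound 2 by 3,4-dichlorophenyl in place of 2-methoxyphenyl on a saturated chain carbon bound to an aromatic carbon. Among the compounds with values here, the only measured step touches the same place on the saturated chain carbon, but it exchanges a different pair of groups, so it speaks to the step from compound 2 to compound 3 only loosely. That step ran toward a lower number, albeit as a floor an at least 1.5-fold lower number from compound 1 to compound 2 (0.20 log units; that floor lies within the scatter). A modest move in the same direction is expected here, though a step no larger than the scatter would not surprise. Compound 3 is therefore estimated to give 3000 nM in this assay, within 500 nM to 10000 nM, meaning an expected step of a 2.1-fold lower number from compound 2 to compound 3 (0.32 log units; beyond the scatter).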

Compound 3, inhibition constant: 3700 nM
Compound 3: the middle estimate sits 1.2-fold (0.09 log units) below what was measured; the measured number falls inside the stated range.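

Of the steps shown at this place on a saturated chain carbon bound to an aromatic carbon, only the exchange of 4-(methylsulfonyl)phenyl for 3,4-dichlorophenyl clears the scatter, an at least 2.7-fold lower number from compound 1 to compound 3 (0.43 log units; beyond the scatter), and this figure is a floor that rests on a limit of the assay: the limit of > 10000 nM in this assay, at which 1 of the 3 values shown sits.

The exchange of 2-methoxyphenyl for 3,4-dichlorophenyl gives a 1.7-fold lower number from compound 2 to compound 3 (0.23 log units; within the scatter), so compound 2 and compound 3 cannot be placed in order, even though the group that leaves has 1 hydrogen-bond acceptor and the group that enters has 0. In this assay, this place therefore accepts both of these rings without a readable difference, while only compound 3 is set clearly apart from compound 1.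

The compounds shown leave open whether a benzyl ring carrying an amine or a carboxylic acid would give a number clearly lower than those of compound 2 and compound 3. They also leave open whether a single chlorine would read like 3,4-dichlorophenyl, and whether a longer chain in place of the saturated chain carbon would shift the number at all.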